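Swapping chloro for bromo on a chalcone aryl ring

The source may hold more compounds than are shown below. What is called first, only, known or untested is meant among the compounds shown, and "the series" means these compounds.

Compound 1, `COc1cc(O)c(C(=O)/C=C/c2ccc(F)cc2)c(OC)c1`: in a functional assay on MDA-MB-231 cells (Homo sapiens) for cytotoxicity, with a stated time of 48 h (on this read-out lower numbers stand for stronger inhibition and higher numbers for weaker inhibition), compound 1 reaches only the assay limit, > 20000 nM.
Compound 2, `COc1cccc(/C=C/C(=O)c2c(OC)cc(OC)cc2OC)c1`: compound 2 gives 8700 nM.
Compound 3, `COc1cc(OC)c(C(=O)/C=C/c2ccc(Cl)cc2)c(OC)c1`: compound 3 gives 8200 nM.

Among the compounds with values here, only two of the three compounds give a number, and compound 3 is one of them. The measured step between them is a 1.1-fold lower number from compound 2 to compound 3 (0.03 log units; within the scatter), a step that lies within the scatter, so compound 2 and compound 3 cannot be told apart on these data. The step from compound 2 to compound 3 exchanges 3-methoxyphenyl for 4-chlorophenyl, a change of a whole substituent rather than of one halogen for another.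

Compound 4, `COc1cc(OC)c(C(=O)/C=C/c2ccc(Br)cc2)c(OC)c1`, has not yet been measured. It differs from compound 3 by bromo in place of chloro on an aromatic carbon. Within the data shown here, no measured step exchanges one halogen for another, so nothing among the measured compounds speaks directly to this change; the one measured step involving the chloro compound is itself within the scatter. The expectation for compound 4 is therefore a step no larger than the scatter, a 1.1-fold lower number from compound 3 to compound 4 (0.04 log units; within the scatter), in no particular direction. Compound 4 is estimated at 7500 nM, with a range from 3000 nM to 20000 nM.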

Compound 4, half-maximal inhibitory concentration: 11100 nM
For compound 4 the middle estimate is 1.5-fold (0.17 log units) below the measured one; measured number inside the range.
By their numbers in this assay, from the lowest: compounds 3, 2 and 4 (each within the scatter of the next). At a limit, above all of these: compound 1.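

Within the data shown here, the bromo compound gives the first direct look at one halogen exchanged for another on this aromatic carbon, para to a large group, and in this assay the exchange gives a 1.4-fold higher number from compound 3 to compound 4 (0.13 log units; within the scatter), so chloro and bromo cannot be told apart at this place. The comparison with the methoxy compound reads the same way, with a 1.3-fold higher number from compound 2 to compound 4 (0.11 log units; within the scatter), which means that 4-bromophenyl, 4-chlorophenyl and 3-methoxyphenyl all fall within the scatter of one another on this chain, and none of the three can be ranked against the others. Nothing available on these compounds bears on why the swap of halogens leaves the number within the scatter.

On these data alone, compound 1 carries fluoro at the same place but differs elsewhere as well, and its > 20000 nM is a limit of the assay, so the effect of fluoro alone on the core of compound 3 remains open. Also open, as far as these compounds go, is whether a group of a different kind at this place, such as an amine or a carboxylic acid, would give a step beyond the scatter.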